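A Side-Chain Swap on a Quinoline-Free Urea Scaffold Core

A few compounds are considered here, and "the series" means these few. Any claim that something is new, unique, unknown or untested is made for them only; others in the source may bear on it.

Two compounds of this series have been looked at in a functional assay on MDA-MB-231 cells (Homo sapiens) for antiproliferative activity, read by MTT assay, with a stated time of 72 h; a higher number here means a weaker inhibitor, a lower number a stronger inhibitor. Compound 1, `COc1cc2c(Oc3ccc(NC(=O)NN4C(=O)CSC4c4c(F)cccc4F)c(Cl)c3)ccnc2cc1OCCCN1CCCC1`, went through the work without a result being reported: in this assay compound 1 stands as "not determined" (no result reported), so no number stands for it. Among the measured compounds shown here, compound 2, `CCN1CCN(CCCOc2cc3nccc(Oc4c(F)cc(NC(=O)NN5C(=O)CSC5c5c(F)cccc5F)cc4F)c3cc2OC)CC1`, is therefore the only compound with a value: in this assay compound 2 gives 3100 nM, and it is the single point of reference for everything that follows.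

The next compound is compound 3, `COc1cc2c(Oc3c(F)cc(NC(=O)NN4C(=O)CSC4c4c(F)cccc4F)cc3F)ccnc2cc1OCCCN1CCC(N2CCCCC2)CC1`. It keeps the whole of compound 2 except for one end of the side chain, where the change is 4-(piperidin-1-yl)piperidin-1-yl in place of 4-ethylpiperazin-1-yl on a saturated chain carbon, three bonds along the chain from an oxygen on an aromatic ring. In plain words, one saturated ring bearing a short ethyl arm is exchanged for two saturated rings joined to one another, and the position of the change on the chain is unaltered.

For the measured compounds named here, no pair of measured compounds shows what such an exchange does here. Going by the values given here, there is no measured step to lean on. The expectation is a small step from compound 2 to compound 3 of a 1.2-fold lower number from compound 2 to compound 3 (0.09 log units; within the scatter), within the usual scatter. For compound 3 the estimated result in this assay is 2500 nM, with a plausible range from 800 nM to 8000 nM.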

Compound 3, half-maximal inhibitory concentration: 5380 nM
For compound 3 the middle estimate is 2.2-fold (0.33 log units) below the measured one; low and high end bracket the measured number.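

At the end of the side chain, on a saturated chain carbon, three bonds along the chain from an oxygen on an aromatic ring, putting 4-(piperidin-1-yl)piperidin-1-yl in place of 4-ethylpiperazin-1-yl gives a 1.7-fold higher number from compound 2 to compound 3 (0.24 log units; within the scatter) in this assay. Among the compounds shown here, this is the first measured step at this position, and it shows that a group of 12 heavy atoms with two saturated rings and a group of 8 heavy atoms with one saturated ring cannot be told apart here, as the two results lie within the usual scatter of repeated measurements. No measured property of either group is available to account for this result.

As far as these compounds go, whether the read-out would stay the same with a morpholine ring, a primary amine or a longer chain at this place remains open, as does the effect of any change elsewhere on the shared core. In this assay compound 1 gives "not determined" (no result reported), so it offers no further comparison, and a single step between two groups supports no general rule about this position.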